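This account rests on a few compounds, and the source may have more. Where it says the series, first, only, none or still open, it means among the compounds named here.

The measured compounds in a functional assay on HCT-116 cells (Homo sapiens) for antiproliferative activity (a lower number here means a stronger inhibitor, a higher number a weaker inhibitor), are:
compound 1 `COCCC(=O)N1CCc2c(C)c3c(n2-c2ccc(C(N)=O)c(c2)N[C@@H](C)[C@H](C)C1)CC(C)(C)CC3=O` with 38 nM,
compound 2 `Cc1c2c(n3c1CCN(C(=O)[C@@H](N)C(C)C)C[C@@H](C)[C@H](C)Nc1cc-3ccc1C(N)=O)CC(C)(C)CC2=O` with 30 nM,
compound 3 `Cc1c2c(n3c1CCN(C(=O)C(C)(C)N)C[C@@H](C)[C@H](C)Nc1cc-3ccc1C(N)=O)CC(C)(C)CC2=O` with 25 nM.

Compound 3 gives the lowest of the three numbers, yet its steps from the others, a 1.5-fold lower number from compound 1 to compound 3 (0.18 log units; within the scatter) and a 1.2-fold lower number from compound 2 to compound 3 (0.08 log units; within the scatter), lie within the scatter, so no order among the three can be drawn. Compound 4 `Cc1c2c(n3c1CCN(C(=O)C1(N)CC1)C[C@@H](C)[C@H](C)Nc1cc-3ccc1C(N)=O)CC(C)(C)CC2=O` is the next step; the change is 1-aminocyclopropyl in place of 1-amino-1-methylethyl on a carbonyl carbon. Going by the values given here, the steps that bear on it are the three exchanges made on the same carbonyl carbon: a 1.3-fold lower number from compound 1 to compound 2 (0.10 log units; within the scatter), a 1.5-fold lower number from compound 1 to compound 3 (0.18 log units; within the scatter) and a 1.2-fold lower number from compound 2 to compound 3 (0.08 log units; within the scatter), none of them beyond the scatter. For compound 4 the expected step is therefore a 1.0-fold higher number from compound 3 to compound 4 (0.02 log units; within the scatter), with no direction beyond the scatter. Compound 4 is estimated at 26 nM, in the range 12 nM to 55 nM.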

Compound 4, half-maximal inhibitory concentration: 81 nM
Estimate against measurement, compound 4: 3.1-fold (0.49 log units) below; the whole stated range lies below it.
By their numbers in this assay, from the lowest: compounds 3, 2 and 1 (each within the scatter of the next); then compound 4.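

In this assay, going by these compounds alone, exchanges on this carbonyl carbon had so far moved the number only within the scatter, but tying the 1-amino-1-methylethyl group into 1-aminocyclopropyl, with the same heavy atom count, gives a 3.2-fold higher number from compound 3 to compound 4 (0.51 log units; beyond the scatter). The ring also sets compound 4 apart from the other two compounds, with a 2.7-fold higher number from compound 2 to compound 4 (0.43 log units; beyond the scatter) and a 2.1-fold higher number from compound 1 to compound 4 (0.33 log units; beyond the scatter), so this position does respond to the change. Nothing available explains this step. The compounds shown leave open whether a larger ring, such as 1-aminocyclobutyl, would behave like 1-aminocyclopropyl. They also leave open whether the shift depends on the amine, which 1-hydroxycyclopropyl on the same carbonyl carbon would address.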